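The source may hold more compounds than are shown below. What is called first, only, known or untested is meant among the compounds shown, and "the series" means these compounds.

Three compounds with a sulfooxy group on a saturated chain have been tested in a functional assay on RAW264.7 cells (Mus musculus) for cytotoxicity, read by MTT assay, with a stated time of 24 h; a lower number here means a stronger inhibitor, a higher number a weaker inhibitor. Compound 1 `O=S(=O)(O)OCCCCCCCCCC[Te]c1ccccc1` gives 5320 nM, and compound 3 `O=S(=O)(O)OCCCCCCCCCCC[Te]c1ccccc1` gives 7840 nM. Among the measured compounds shown here, compound 3 therefore stands within the scatter of compound 1, the only other compound here with a numerical result. Compound 2 `O=S(=O)(O)OCCCCCCCCC[Se]c1ccccc1` reads > 100000 nM, which is a limit of this assay and not a number.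

The next case is compound 4 `O=S(=O)(O)OCCCCCCCCC[Te]c1ccccc1`, which has selenium replaced by tellurium relative to compound 2. Relative to compound 3, the difference is sulfooxy in place of 2-(sulfooxy)ethyl on a saturated chain carbon, nine bonds along the chain from a tellurium atom. For the measured compounds named here, the only measured step of this kind is a 1.5-fold higher number from compound 1 to compound 3 (0.17 log units; within the scatter), so no step beyond the scatter is expected, although this change is larger and one small step gives only a weak guide to direction.

The expected change is a 1.6-fold lower number from compound 3 to compound 4 (0.20 log units; within the scatter). For compound 4 the estimate is 5000 nM, with an expected range from 1800 nM to 16000 nM.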

Compound 4, half-maximal inhibitory concentration: 4670 nM
Estimate against measurement, compound 4: 1.1-fold (0.03 log units) above; measured number inside the range.
By their numbers in this assay, from the lowest: compounds 4, 1 and 3 (each within the scatter of the next). At a limit, above all of these: compound 2.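

In this assay, among the compounds shown here, replacing selenium with tellurium at a single atom gives the first step here beyond the scatter, an at least 21-fold lower number from compound 2 to compound 4 (1.33 log units; beyond the scatter). Compound 2 reads as a limit and not a number: the limit of > 100000 nM in this assay, at which 1 of the 4 values shown sits.

Sulfooxy in place of 2-(sulfooxy)ethyl gives a 1.7-fold lower number from compound 3 to compound 4 (0.22 log units; within the scatter), and sulfooxy in place of (sulfooxy)methyl gives a 1.1-fold lower number from compound 1 to compound 4 (0.06 log units; within the scatter); both stay within the scatter, so no effect of chain length can be read among these tellurium compounds.

For the compounds shown here, only one selenium compound appears, so it remains open whether the difference between selenium and tellurium holds at other chain lengths. Also open, on these data alone, is what a carboxylic acid in place of sulfooxy, or a much shorter chain, would do to the number.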